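A Methoxy Added to the Hydroxyphenyl Ring

The source may hold more compounds than are shown below. What is called first, only, known or untested is meant among the compounds shown, and "the series" means these compounds.

Compound 1 `Cc1ccc(-c2nc3c(c(-c4ccccc4)nn3-c3ccccc3)c(-c3ccc(O)cc3)c2C#N)cc1` and compound 2 `N#Cc1c(-c2ccco2)nc2c(c(-c3ccccc3)nn2-c2ccccc2)c1-c1ccc(O)cc1` share one core and differ only in the group on one aromatic carbon. In a functional assay on MV4-11 cells (Homo sapiens) for antiproliferative activity, read by resazurin assay, with a stated time of 72 h (a lower number here means a stronger inhibitor, a higher number a weaker inhibitor), compound 1 gives 3300 nM, and compound 2 gives 13800 nM. Among the compounds with values here, the one measured step, a 4.2-fold higher number from compound 1 to compound 2 (0.62 log units; beyond the scatter), concerns a change at a different position from the one now considered, so it offers no direct guide. Among the two numbers known, compound 2 stands as the highest, with compound 1 its only neighbour.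

Compound 3 `COc1cc(-c2c(C#N)c(-c3ccco3)nc3c2c(-c2ccccc2)nn3-c2ccccc2)ccc1O` differs from compound 2 by methoxy in place of hydrogen on an aromatic carbon. Within the data shown here, no measured pair here tells what a methoxy in that place does, so the step in this assay is expected to stay within the scatter, in no firm direction, amounting to a 1.2-fold lower number from compound 2 to compound 3 (0.06 log units; within the scatter). Compound 3 is therefore estimated at 12000 nM, with a range from 5000 nM to 30000 nM.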

Compound 3, half-maximal inhibitory concentration: 35300 nM
Beside the measured number, compound 3's estimate is 2.9-fold (0.47 log units) below it, outside the stated range (above it).
By their numbers in this assay, from the lowest: compound 1; then compound 2; then compound 3.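

Adding a methoxy ortho to a hydroxy group, which turns 4-hydroxyphenyl into 4-hydroxy-3-methoxyphenyl, weakens the compound in this assay, with a 2.6-fold higher number from compound 2 to compound 3 (0.41 log units; beyond the scatter). Within the data shown here, this is the first measured change on the hydroxyphenyl ring, and it shows that this ring position is sensitive to substitution: even a group this small moves the number beyond the scatter, though the step is modest. No measurement shown here accounts for the weakening.

The compounds shown leave open whether the loss is specific to methoxy or would also follow from another group in the same place, such as an amine, a fluorine atom or a longer chain like ethoxy. On these data alone, it is also open whether methoxy would cost as much with 4-methylphenyl in place of furan-2-yl, the group that compound 1 carries.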